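Replacing an anilide with a diethylamide on a shared core

This account rests on a few compounds, and the source may have more. Where it says the series, first, only, none or still open, it means among the compounds named here.

Three compounds share one core, differing only in the group attached to the carbonyl carbon. In a functional assay on HL-60 cells (Homo sapiens) for antiproliferative activity, read by MTT assay, with a stated time of 48 h (on this read-out higher numbers stand for weaker inhibition and lower numbers for stronger inhibition), compound 1 `C=CC(=O)Nc1ccc(-c2nc(Cl)cc(Nc3ccc(C(=O)Nc4ccc(F)cc4)cc3)n2)cc1` gives "not determined" (no result reported) and compound 2 `C=CC(=O)Nc1ccc(-c2nc(Cl)cc(Nc3ccc(C(=O)Nc4ccc(OC)cc4)cc3)n2)cc1` gives "not determined" (no result reported), so neither has a reported number. For the measured compounds named here, compound 3 `C=CC(=O)Nc1ccc(-c2nc(Cl)cc(Nc3ccc(C(=O)Nc4cccc(C)c4)cc3)n2)cc1` is the only one with a value: in this assay compound 3 gives 3660 nM, so it stands alone, with no measured neighbour to compare against. Compound 4 `C=CC(=O)Nc1ccc(-c2nc(Cl)cc(Nc3ccc(C(=O)N(CC)CC)cc3)n2)cc1` differs from compound 3 by diethylamino in place of (3-methylphenyl)amino on a carbonyl carbon. Going by the values given here, no measured step exists for this kind of change here. A step toward weaker inhibition, somewhat beyond the scatter, is expected from compound 3 to compound 4, a 1.9-fold higher number from compound 3 to compound 4 (0.28 log units; within the scatter). Compound 4 is therefore expected to give about 7000 nM in this assay, within 2500 nM to 20000 nM.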

Compound 4, half-maximal inhibitory concentration: 9340 nM
For compound 4 the middle estimate is 1.3-fold (0.13 log units) below the measured one; the range from low to high includes it.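

In this assay, for the compounds shown here, the change at this carbonyl carbon gives a 2.6-fold higher number from compound 3 to compound 4 (0.41 log units; beyond the scatter), the first measured step at this position. Compound 4 keeps measurable activity after losing the six-membered aromatic ring and the hydrogen-bond donor of the (3-methylphenyl)amino group, while any steps involving compound 1 or compound 2 cannot be read. Nothing available explains this shift. The compounds shown do not separate the loss of the ring from the loss of the amide hydrogen. On these data alone, how a piperidine or morpholine amide, or a simple N-methylanilide, would read at this carbonyl carbon remains open.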